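From amino to hydroxy: compound 3 to compound 4

The source may report more compounds than this note shows. Statements on the series, on what has been measured and on what is new or still open speak of the compounds shown alone.

For the measured compounds named here, in a functional assay (Homo sapiens) for inhibition, read by sulforhodamine B assay, with a stated time of 3 days (on this read-out lower numbers stand for stronger inhibition and higher numbers for weaker inhibition), compound 3 `NCCNc1nc(N2CCCC2)c2nc(Cl)c(NCc3ccccc3)nc2n1` gives 3200 nM, the lowest of the three numbers so far. Compound 1 `CN1CCN(c2nc(N3CCCC3)c3nc(Cl)c(NCc4ccccc4)nc3n2)CC1` gives 6500 nM and compound 2 `CC(=O)N1CCN(c2nc(N3CCCC3)c3nc(Cl)c(NCc4ccccc4)nc3n2)CC1` gives 13000 nM. The next change leads to compound 4 `OCCNc1nc(N2CCCC2)c2nc(Cl)c(NCc3ccccc3)nc2n1` and reads (hydroxy in place of amino on a saturated chain carbon, two bonds along the chain from a nitrogen on an aromatic ring), with hydroxy in place of amino on a saturated chain carbon, two bonds along the chain from a nitrogen on an aromatic ring. Going by the values given here, no measured step makes this exact exchange. The evidence is indirect: a 2.0-fold lower number from compound 1 to compound 3 (0.31 log units; beyond the scatter) and a 4.1-fold lower number from compound 2 to compound 3 (0.61 log units; beyond the scatter) each put (2-aminoethyl)amino on an aromatic carbon, while a 2.0-fold higher number from compound 1 to compound 2 (0.30 log units; within the scatter) stays within the scatter. These modest steps do not separate the amino end from the rest of the chain. A modest rise in this assay is therefore expected, close to the scatter. The expected step is a 1.7-fold higher number from compound 3 to compound 4 (0.24 log units; within the scatter). Compound 4 is estimated at 5500 nM, with an expected range from 2300 nM to 13000 nM.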

Compound 4, half-maximal inhibitory concentration: 15200 nM
Beside the measured number, compound 4's estimate is 2.8-fold (0.44 log units) below it; measured number outside the range, above it.
By their numbers in this assay, from the lowest: compound 3; then compounds 1, 2 and 4 (each within the scatter of the next, the first and the last beyond it).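

In this assay, for the compounds shown here, the exchange of amino for hydroxy at the chain end gives a 4.8-fold higher number from compound 3 to compound 4 (0.68 log units; beyond the scatter), so this terminal atom alone affects the number, which the earlier steps could not show because they replaced the whole substituent. The (2-hydroxyethyl)amino group does not repeat the lower number that (2-aminoethyl)amino gave against the piperazines: it gives a 2.3-fold higher number from compound 1 to compound 4 (0.37 log units; beyond the scatter) and a 1.2-fold higher number from compound 2 to compound 4 (0.07 log units; within the scatter), the second within the scatter. Nothing measured here bears on the reason for the rise on this exchange.

Open, as far as these compounds go, is whether a methylamino or dimethylamino end, or a longer chain carrying the amine, would hold or lower the number of compound 3. Also open, from the compounds shown here alone, is whether a carboxylic acid at the chain end would fall nearer compound 3 or compound 4.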